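Ethyl to cyclopropyl on the shared core: clearance notes

This account rests on a few compounds, and the source may have more. Where it says the series, first, only, none or still open, it means among the compounds named here.

Three compounds with the shared core and an ethyl group on an aromatic nitrogen have been measured. They differ only in the group on an aromatic carbon. In an ADME assay on microsomes from liver (Homo sapiens) for metabolic stability (on this read-out lower numbers stand for slow clearance and higher numbers for fast clearance), compound 1 (`CCn1cnc2c(-c3ccc(F)c(-c4cnn(C)c4)c3)cnnc21`) gives 47 mL.min-1.g-1, compound 2 (`CCn1cnc2c(-c3ccc(F)c(OCc4ccccn4)c3)cnnc21`) gives 41 mL.min-1.g-1 and compound 3 (`CCn1cnc2c(-c3ccc(F)c(Oc4ccc(C#N)cn4)c3)cnnc21`) gives 65 mL.min-1.g-1.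

Compound 3 is not separated from the other two. The data show a 1.4-fold higher number from compound 1 to compound 3 (0.14 log units; within the scatter) and a 1.6-fold higher number from compound 2 to compound 3 (0.20 log units; within the scatter). The remaining step, a 1.1-fold lower number from compound 1 to compound 2 (0.06 log units; within the scatter), is no different in kind.

Compound 4 (`N#Cc1ccc(Oc2cc(-c3cnnc4c3ncn4C3CC3)ccc2F)nc1`) keeps the (5-cyanopyridin-2-yl)oxy group of compound 3 and has cyclopropyl in place of ethyl on an aromatic nitrogen. Within the data shown here, no measured compound varies at that nitrogen, so none of the three steps tests this change directly. Among the measured compounds shown here, they show only that the numbers in this assay stayed within the scatter when the other group was exchanged. No step beyond the scatter is therefore expected, and the data give no firm direction. The estimated step is a 1.1-fold lower number from compound 3 to compound 4 (0.03 log units; within the scatter). For compound 4 the expected value is 60 mL.min-1.g-1, with an estimated range from 35 mL.min-1.g-1 to 100 mL.min-1.g-1.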

Compound 4, intrinsic clearance in microsomes: 17 mL.min-1.g-1
Beside the measured number, compound 4's estimate is 3.5-fold (0.55 log units) above it, outside the stated range (below it).
By their numbers in this assay, from the lowest: compound 4; then compounds 2, 1 and 3 (each within the scatter of the next).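

Among these compounds, at the aromatic nitrogen of the five-membered ring, cyclopropyl in place of ethyl gives in this assay a 3.8-fold lower number from compound 3 to compound 4 (0.58 log units; beyond the scatter) and is the only step in this set beyond the scatter. The exchanges on the aromatic carbon among compound 1, compound 2 and compound 3 all stayed within the scatter, so this nitrogen is the one position here at which the read-out has moved, though the reading rests on a single matched pair carrying the (5-cyanopyridin-2-yl)oxy group. Nothing measured here accounts for the size or direction of this step.

Still open is whether cyclopropyl gives a similar step with 1-methyl-1H-pyrazol-4-yl or (pyridin-2-yl)methoxy on the aromatic carbon, as the only matched pair shown carries the (5-cyanopyridin-2-yl)oxy group. Also open, as far as these compounds go, is whether the three-membered ring or the extra carbon goes with the lower number, a question that isopropyl, n-propyl or cyclobutyl on the same nitrogen could help to separate.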